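A Second Fluoro on the Bis(benzylidene)cyclohexanone Scaffold

The compounds below may be only part of what the source reports. "The series", "measured", "known", "first", "only" and "open" are said of these compounds alone.

The measured compounds and their values:
compound 1 `O=C1/C(=C/c2ccccc2)CCC/C1=C\c1ccc(Cl)cc1`: 27.6%
compound 2 `O=C1/C(=C/c2ccccc2)CCC/C1=C\c1ccc(O)cc1`: 53%
compound 3 `O=C1/C(=C/c2ccccc2)CCC/C1=C\c1ccc(F)cc1`: 34%

All three share one core and differ only in the group on one aromatic ring. In an assay on isolated protein for inhibition of Alpha glucosidase (Homo sapiens), with stated times of 5 min and 15 min, tested at 50 uM (a lower number here means less inhibition, a higher number more inhibition at the concentration tested (going by the name of the read-out)), compound 3 gives 34%, the second highest of the three numbers. One of its two steps is a number 6.4 percentage points higher from compound 1 to compound 3 (within the scatter), and the other is a number 19 percentage points lower from compound 2 to compound 3 (beyond the scatter), so only the hydroxy compound stands clearly apart.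

Compound 4 `O=C1/C(=C/c2ccccc2)CCC/C1=C\c1ccc(F)c(F)c1` carries a change of fluoro in place of hydrogen on an aromatic carbon. Within the data shown here, no measured step adds a second group to this ring; the closest precedent is the swap of one halogen for another, a number 6.4 percentage points higher from compound 1 to compound 3 (within the scatter), which stayed within the scatter. A second fluoro is therefore expected to move the read-out little, with a number 2 percentage points higher from compound 3 to compound 4 (within the scatter) as the expected step. Compound 4 is estimated at 36%, between 18% and 54%.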

Compound 4, a percentage reported as inhibition, at one concentration (the size of the read-out at that concentration, not a potency): 37.8%
Beside the measured number, compound 4's estimate is 1.8 percentage points below it; the measured number falls inside the stated range.
By their numbers in this assay, from the lowest: compounds 1, 3 and 4 (each within the scatter of the next, the first and the last beyond it); then compound 2.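

Adding a fluoro group to the ring of compound 3, ortho to a fluoro group and meta to a large group, gives in this assay a number 3.8 percentage points higher from compound 3 to compound 4 (within the scatter). Among these compounds, the earlier compounds only exchanged one group for another at a single place on the ring, so this is the first sign that a second group can be added to that ring with no change that can be told apart from the usual scatter. Nothing available here bears on the reason for this result.

Still open, as far as these compounds go, is whether a hydroxy group at this new position would raise the read-out, as the exchange of chloro for hydroxy did in a number 25.4 percentage points higher from compound 1 to compound 2 (beyond the scatter). Also open, from the compounds shown here alone, is how a larger group here, such as an amine or a carboxylic acid, would compare with the second fluoro.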